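From 2,6-Dimethylphenyl to 3,5-Dimethylphenyl

The source may hold more compounds than are shown below. What is called first, only, known or untested is meant among the compounds shown, and "the series" means these compounds.

In a functional assay on KB cells (Homo sapiens) for cytotoxicity (on this read-out higher numbers stand for an effect only at larger amounts of compound and lower numbers for an effect already at smaller amounts), compound 2 `COC1=C(C)C(=O)/C(=C(O)/C=C/c2c(C)cccc2C)C(=O)C1(C)C` gives 2.1 ug/mL, and compound 1 `COC1=C(C)C(=O)/C(=C(O)/C=C/c2ccc(C)cc2)C(=O)C1(C)C` gives 1.9 ug/mL. Among the measured compounds shown here, these two values cannot be told apart: the only measured step, a 1.1-fold higher number from compound 1 to compound 2 (0.04 log units; within the scatter), stays within the scatter. Compound 3 `COC1=C(C)C(=O)/C(=C(O)/C=C/c2cc(C)cc(C)c2)C(=O)C1(C)C` keeps the shared core of compound 2 and differs only in the group on the chain, with 3,5-dimethylphenyl in place of 2,6-dimethylphenyl on a double-bonded chain carbon bound to a double-bonded chain carbon. For the measured compounds named here, no measured compound yet carries the 3,5-dimethylphenyl group, so the one available guide is the exchange at this same place from compound 1 to compound 2, which gave a 1.1-fold higher number from compound 1 to compound 2 (0.04 log units; within the scatter). No change beyond the scatter is therefore expected in this assay, and the estimated step is a 1.1-fold lower number from compound 2 to compound 3 (0.02 log units; within the scatter). For compound 3 the estimate is 2 ug/mL, with an expected range from 1 ug/mL to 4 ug/mL.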

Compound 3, concentration for half-maximal effect: 1.6 ug/mL
Beside the measured number, compound 3's estimate is 1.3-fold (0.10 log units) above it; low and high end bracket the measured number.
By their numbers in this assay, from the lowest: compounds 3, 1 and 2 (each within the scatter of the next).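

The exchange of 2,6-dimethylphenyl for 3,5-dimethylphenyl, two groups with the same atoms joined differently, gives a 1.3-fold lower number from compound 2 to compound 3 (0.12 log units; within the scatter) in this assay, and the exchange of 4-methylphenyl for 3,5-dimethylphenyl gives a 1.2-fold lower number from compound 1 to compound 3 (0.07 log units; within the scatter) in the same read-out. With three methyl-bearing phenyl groups now compared on a double-bonded chain carbon bound to a double-bonded chain carbon, neither rearranging the two methyl groups nor having one methyl group rather than two produces a step beyond the scatter in these compounds. Nothing is available that would account for this flat result.

Going by these compounds, all three compounds carry only methyl groups on the phenyl, so it remains open whether a methoxy group, a chlorine atom, an amine or a carboxylic acid there would shift the number beyond the scatter. Also open, on these data alone, is how the unsubstituted phenyl would compare.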